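The source may report more compounds than this note shows. Statements on the series, on what has been measured and on what is new or still open speak of the compounds shown alone.

Of the compounds shown here, two sharing one core have been tested in an ADME assay on BJ cells (Homo sapiens) for antiproliferative activity, with a stated time of 72 h; a lower number here means that less compound is needed, a higher number that more compound is needed for the effect. Compound 1 `COc1ccc(-c2cc(=O)c3c(OC)cc(OC)cc3n2Cc2ccccc2)cc1` carries a benzyl on its aromatic nitrogen. In this assay compound 1 gives > 34400 nM, which is a limit of the assay rather than a number. Compound 2 `COc1ccc(-c2cc(=O)c3c(OC)cc(OC)cc3n2S(=O)(=O)c2ccc(Cl)cc2)cc1` carries a (4-chlorophenyl)sulfonyl instead of that benzyl. In this assay compound 2 gives > 34400 nM, again a limit of the assay and not a number. The step that the two limits leave unreadable from compound 1 to compound 2 cannot be read from two limits. Both values sit at the limit of > 34400 nM in this assay, at which 2 of the 2 values shown sit, so compound 2 stands only as a limit, with no number of its own. Compound 3 `COc1ccc(-c2cc(=O)c3c(OC)cc(OC)cc3n2S(=O)(=O)Cc2ccccc2)cc1` differs from compound 2 by benzyl in place of 4-chlorophenyl on a sulfonyl sulfur. For the measured compounds named here, no measured step speaks to this change; the only one, a step that the two limits leave unreadable from compound 1 to compound 2, is unreadable. The expected step that the limit leaves unreadable from compound 2 to compound 3 is therefore none beyond the scatter. Compound 3 is expected to give an estimate of 50000 nM in this assay, with a range from 15000 nM to 150000 nM, most likely reported once more only as a limit.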

Compound 3, half-maximal effective concentration: > 34400 nM
Compound 3 ended at the assay's limit (the forecaster's own chance of this, stated with the estimate: 80%); the middle value lies beyond the limit too.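

In this assay, no step can be read among compound 1, compound 2 and compound 3, since each stands only as a limit and not as a number: the limit of > 34400 nM in this assay, at which 3 of the 3 values shown sit.

From the compounds shown here alone, whether benzyl, (4-chlorophenyl)sulfonyl or benzylsulfonyl on the aromatic nitrogen makes any difference in this assay stays open.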